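A few compounds are considered here, and "the series" means these few. Any claim that something is new, unique, unknown or untested is made for them only; others in the source may bear on it.

In a functional assay on A549 cells (Homo sapiens) for antiproliferative activity, read by sulforhodamine B assay, with a stated time of 72 h (on this read-out higher numbers stand for weaker inhibition and lower numbers for stronger inhibition), two compounds have been measured so far:

- compound 1 `COc1ccc(O)c(C(=O)/C=C/c2csc3ccccc23)c1`: 580 nM
- compound 2 `CC(C)Oc1ccc(O)c(C(=O)/C=C/c2csc3ccccc23)c1`: 6400 nM

Compound 1 holds the lower of these two numbers, which means the stronger inhibition. Going by the values given here, its only measured neighbour is compound 2, and the gap is an 11-fold higher number from compound 1 to compound 2 (1.04 log units; beyond the scatter), with isopropyl in place of methyl on an oxygen on an aromatic ring.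

Compound 3 `COc1ccc(OC)c(C(=O)/C=C/c2csc3ccccc23)c1` has not yet been measured. It differs from compound 1 in one place: methyl in place of hydrogen on an oxygen on an aromatic ring. This puts methyl in place of hydrogen on an oxygen on an aromatic ring, so a hydroxy becomes a methoxy.

Among the compounds with values here, the single measured step bears on this change only loosely. It is large and beyond the scatter, so this assay clearly responds to a change on such an oxygen. However, that step concerns the other oxygen, and no measured compound shows the hydroxy being replaced. A moderate step towards a higher number is therefore expected, with wide uncertainty.

For compound 3 the estimated value is 900 nM, with an expected range from 200 nM to 4000 nM.

This estimate means an expected 1.6-fold higher number from compound 1 to compound 3 (0.19 log units; within the scatter).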

Compound 3, half-maximal inhibitory concentration: 4100 nM
Compound 3: the middle estimate sits 4.6-fold (0.66 log units) below what was measured; measured number outside the range, above it.
By their numbers in this assay, from the lowest: compound 1; then compounds 3 and 2 (each within the scatter of the next).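

In this assay, turning the hydroxy of compound 1 into a methoxy gives a 7.1-fold higher number from compound 1 to compound 3 (0.85 log units; beyond the scatter), so the assay also responds to a change on this oxygen, which the earlier pair had left untouched. Adding a single methyl here is enough to produce a step beyond the scatter, which shows that the free hydroxy cannot be capped in this way without losing inhibition in this assay. Both single changes now shown, this one and the one on the other oxygen with an 11-fold higher number from compound 1 to compound 2 (1.04 log units; beyond the scatter), lead away from compound 1 to weaker inhibition, and nothing shown here accounts for either step.

On these data alone, it remains open whether the loss on this oxygen is particular to the methyl or would recur with a longer chain such as ethyl or with an acetyl group. As far as these compounds go, it is equally open whether replacing the hydroxy outright, for instance with an amine or a fluorine atom, would keep the number close to that of compound 1.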